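A few compounds are considered here, and "the series" means these few. Any claim that something is new, unique, unknown or untested is made for them only; others in the source may bear on it.

Values in a functional assay on HUVEC cells (Homo sapiens) for antiproliferative activity, read by MTT assay, with a stated time of 48 h; on this read-out higher numbers stand for weaker inhibition and lower numbers for stronger inhibition:
- Compound 1 `Cc1cccc(/C=C/c2nnc(-c3ccc4c(c3)OCCO4)o2)c1`: 40600 nM
- Compound 2 `Cc1ccc(/C=C/c2nnc(-c3ccc4c(c3)OCCO4)o2)cc1`: 45200 nM
- Compound 3 `C(=C/c1nnc(-c2ccc3c(c2)OCCO3)o1)\c1ccccc1`: > 50000 nM (a limit, not a number)

Compound 3 has no number of its own, only a limit: the limit of > 50000 nM in this assay, at which 1 of the 3 values shown sits. Compound 4 `COc1cccc(/C=C/c2nnc(-c3ccc4c(c3)OCCO4)o2)c1` differs from compound 3 by methoxy in place of hydrogen on an aromatic carbon, meta to a large group. Within the data shown here, no measured step involves methoxy. The nearest evidence is the pair of methyl-to-hydrogen changes, an at least 1.2-fold higher number from compound 1 to compound 3 (0.09 log units; that floor lies within the scatter) and an at least 1.1-fold higher number from compound 2 to compound 3 (0.04 log units; that floor lies within the scatter), whose floors both lie within the scatter. Moving the methyl made no difference beyond the scatter either, as a 1.1-fold higher number from compound 1 to compound 2 (0.05 log units; within the scatter) shows. Compound 1 carries 3-methylphenyl where compound 4 carries 3-methoxyphenyl, and compound 1 gives 40600 nM, so it is the closest guide. On that basis, no step beyond the scatter is expected in this assay, and any shift should be towards a lower number. The expected step is an at least 1.1-fold lower number from compound 3 to compound 4 (0.07 log units; that floor lies within the scatter). A reading at the limit would be no surprise. For compound 4 the estimate is 42000 nM, with an expected range of 22000 nM to 75000 nM.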

Compound 4, half-maximal inhibitory concentration: > 50000 nM
Compound 4 ended at the assay's limit; the forecaster's own chance of this, stated with the estimate: 40%; middle value at least 1.1-fold (0.07 log units) from the limit.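

In this assay compound 4, with 3-methoxyphenyl, gives only a limit, as does compound 3, so the step between these two cannot be read and methoxy shows no readable effect against hydrogen. Against the methyl compounds, methoxy in place of methyl on an aromatic carbon gives an at least 1.2-fold higher number from compound 1 to compound 4 (0.09 log units; that floor lies within the scatter), and 3-methoxyphenyl in place of 4-methylphenyl gives an at least 1.1-fold higher number from compound 2 to compound 4 (0.04 log units; that floor lies within the scatter). Both floors lie within the scatter, so methoxy at this place is not separated from methyl either, and the limit now holds a larger share of the series: the limit of > 50000 nM in this assay, at which 2 of the 4 values shown sit.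

On these data alone, whether an amine, a hydroxyl or a chlorine on this aromatic carbon would bring the reading clearly under the limit stays open. So does the true position of compound 3 and compound 4 beyond their limits.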